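Changing the Amide Cap on a Phosphodiesterase Inhibitor

This account rests on a few compounds, and the source may have more. Where it says the series, first, only, none or still open, it means among the compounds named here.

Compound 3 `CNC(=O)c1ccc(NC(=O)c2cn(Cc3c(F)cccc3F)c3ccc(=O)[nH]c3c2=O)cc1` holds the lowest number in an in vitro assay on Sf21 cells for inhibition of high affinity 3',5'-cyclic-AMP phosphodiesterase 7A (Homo sapiens), read by scintillation proximity assay, with a stated time of 30 min; a higher number here means a weaker inhibitor, a lower number a stronger inhibitor: compound 3 gives 29 nM. Its nearest neighbour, compound 2 `O=C(O)Cc1ccc(NC(=O)c2cn(Cc3c(F)cccc3F)c3ccc(=O)[nH]c3c2=O)cc1`, gives 176 nM in this assay, and the change at the aromatic carbon produced a 6.1-fold lower number from compound 2 to compound 3 (0.78 log units; beyond the scatter). Compound 1 `O=C(Nc1c(F)cccc1F)c1cn(Cc2c(F)cccc2F)c2ccc(=O)[nH]c2c1=O` gives > 1000 nM in this assay, which is a limit and not a number (the limit of > 1000 nM in this assay, at which 1 of the 3 values shown sits). Compound 4 `O=C(Nc1ccc(S(=O)(=O)Nc2nccs2)cc1)c1cn(Cc2c(F)cccc2F)c2ccc(=O)[nH]c2c1=O` differs from compound 3 by (1,3-thiazol-2-yl)sulfamoyl in place of methylcarbamoyl on an aromatic carbon. Among the measured compounds shown here, the steps of an at least 34-fold lower number from compound 1 to compound 3 (1.53 log units; beyond the scatter) and an at least 5.6-fold lower number from compound 1 to compound 2 (0.75 log units; beyond the scatter) show that the group on the amide-type nitrogen matters greatly, while only one step at the aromatic carbon itself has been measured. Some loss is expected, because a 6.1-fold lower number from compound 2 to compound 3 (0.78 log units; beyond the scatter) shows that carboxymethyl is weaker than methylcarbamoyl at this carbon. The expected step is a 2.1-fold higher number from compound 3 to compound 4 (0.32 log units; beyond the scatter). Compound 4 is estimated at 60 nM, within a range from 10 nM to 400 nM.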

Compound 4, half-maximal inhibitory concentration: 25 nM
Beside the measured number, compound 4's estimate is 2.4-fold (0.38 log units) above it; measured number inside the range.
By their numbers in this assay, from the lowest: compounds 4 and 3 (each within the scatter of the next); then compound 2. At a limit, above all of these: compound 1.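

The larger (1,3-thiazol-2-yl)sulfamoyl, with its five-membered aromatic ring, can take the place of methylcarbamoyl on this aromatic carbon: this assay shows a 1.2-fold lower number from compound 3 to compound 4 (0.06 log units; within the scatter) and so no real difference between the two groups. The same group also gives a 7.0-fold lower number from compound 2 to compound 4 (0.85 log units; beyond the scatter) in place of carboxymethyl, so two quite different groups now match at this carbon while carboxymethyl stays apart from both.

As far as these compounds go, whether an amine or a carboxylic acid set directly on this carbon would keep the number this low stays open. No measurement shown gives a reason for these steps.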